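The source may hold more compounds than are shown below. What is called first, only, known or untested is meant among the compounds shown, and "the series" means these compounds.

Measured so far in an ADME assay on a cell-free system (plasma, Homo sapiens) for protein binding:
- compound 1 `CNc1nccc(N2CC[C@H](NC(=O)Nc3ccc(CN4CCC4)c(C(F)(F)F)c3)C2)n1`: 86.3%
- compound 2 `CCN1CCN(Cc2ccc(NC(=O)N[C@H]3CCN(c4ccnc(NC)n4)C3)cc2C(F)(F)F)CC1`: 75.2%

On these two numbers, compound 2 stands within the scatter of compound 1, so the pair cannot be ranked. Among the compounds with values here, the one measured step between them is a 1.8-fold higher unbound fraction from compound 1 to compound 2 (0.26 log units; within the scatter). It placed 4-ethylpiperazin-1-yl where azetidin-1-yl had been, on a saturated chain carbon bound to an aromatic carbon.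

Compound 3 `CNc1nccc(N2CC[C@H](NC(=O)Nc3ccc(CN4CCN(C)CC4)c(C(F)(F)F)c3)C2)n1` has not yet been measured. It differs from compound 2 by a single small edit: hydrogen in place of methyl on a saturated chain carbon bound to an amine nitrogen in a ring. Hydrogen stands in place of methyl on a saturated chain carbon bound to an amine nitrogen in a ring, which turns 4-ethylpiperazin-1-yl into 4-methylpiperazin-1-yl.

Within the data shown here, only one measured step bears on this edit, and it is indirect. Exchanging the entire group in a 1.8-fold higher unbound fraction from compound 1 to compound 2 (0.26 log units; within the scatter) stayed within the scatter, so removing one methyl is expected to do no more. The expected change in this assay is a 1.1-fold higher unbound fraction from compound 2 to compound 3 (0.04 log units; within the scatter), which means no real shift beyond the scatter. For compound 3 the estimate is 73%, with an expected range of 58% to 84%.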

Compound 3, plasma protein binding: 87.6%
Estimate against measurement, compound 3: 2.2-fold (0.34 log units) (unbound fraction) above; the whole stated range lies below it.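

In this assay the change from ethyl to methyl, the loss of a single carbon, gives a 2.0-fold lower unbound fraction from compound 2 to compound 3 (0.30 log units; within the scatter) and so sits at the edge of the scatter, with a step of much the same printed size as the exchange of the whole group between compound 1 and compound 2. Putting 4-methylpiperazin-1-yl in place of azetidin-1-yl gives a 1.1-fold lower unbound fraction from compound 1 to compound 3 (0.04 log units; within the scatter) and shows that these two groups cannot be told apart in this measurement, so none of the three compounds can be ranked and no trend can be drawn for this position. No measured information is available to explain these values.

Going by these compounds, whether a longer chain such as propyl, or a carboxylic acid, in place of the methyl of 4-methylpiperazin-1-yl would carry the read-out clearly beyond the scatter stays open. On these data alone, all three compounds also share the same core, so whether these small steps would hold on a different core remains open too.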